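Side-chain branching in the glucagon receptor antagonist series

A few compounds are considered here, and "the series" means these few. Any claim that something is new, unique, unknown or untested is made for them only; others in the source may bear on it.

Compound 1 `CCC(Oc1ccc(-n2cc(C(F)(F)F)cn2)cc1)c1ccc(C(=O)NCCC(=O)O)cc1` is known in a functional assay on cells for antagonist activity at Glucagon receptor (Homo sapiens), read by cAMP accumulation, in the presence of a further agent that is not named here (a lower number here means a stronger inhibitor, a higher number a weaker inhibitor), only as a limit; in this assay compound 1 gives > 22000 nM. That figure is a limit of the assay and not a number, so compound 1 stands at the weak edge of what the measurement can resolve (the limit of > 22000 nM in this assay, at which 1 of the 2 values shown sits). Compound 2 `CCCC(Nc1ccc(-n2cc(C(F)(F)F)cn2)nc1)c1ccc(C(=O)NCCC(=O)O)cc1` belongs to the same series but differs from compound 1 in more than one place; in this assay compound 2 gives 1300 nM, a number rather than a limit. Within the data shown here, no single-change step between measured compounds is available.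

Compound 3 `CC(C)CC(Oc1ccc(-n2cc(C(F)(F)F)cn2)cc1)c1ccc(C(=O)NCCC(=O)O)cc1` has not been measured. It differs from compound 1 by isopropyl in place of methyl on a saturated chain carbon, two bonds along the chain from an aromatic carbon and an oxygen on an aromatic ring. Since compound 1 sits at a limit, the direction of this change cannot be anchored to any measured step, and the expected movement in this assay is modest at best. Compound 3 is expected to give about 9000 nM in this assay, somewhere between 1500 nM and 30000 nM. The expected step of an at least 2.4-fold lower number from compound 1 to compound 3 (0.38 log units; beyond the scatter) is taken as a small gain that may still leave only a limit reported.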

Compound 3, antagonist equilibrium constant: 3400 nM
For compound 3 the middle estimate is 2.6-fold (0.42 log units) above the measured one; low and high end bracket the measured number.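

In this assay, isopropyl in place of methyl on this saturated chain carbon, which cut one bond further out reads ethyl to isobutyl, gives an at least 6.4-fold lower number from compound 1 to compound 3 (0.81 log units; beyond the scatter). From the compounds shown here alone, the value for compound 1 is a limit and not a number, so the true size of this step stays unknown and only its lower bound can be read: the limit of > 22000 nM in this assay, at which 1 of the 3 values shown sits. Compound 3 thus shows what compound 1 could not: with the oxygen on the aromatic ring kept in place, this position can carry the larger isobutyl chain and still give a measured number, so the position responds to a change in this chain.

Going by these compounds, whether the gain belongs to the branch itself or simply to the longer chain stays open, and a straight butyl chain or a cyclopentyl group on the same carbon would separate these two readings. On these data alone, compound 2 differs from compound 3 in more than one place, so its value cannot be read against this step, and whether the same chain change would carry over to the core of compound 2 remains unknown.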